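The source may hold more compounds than are shown below. What is called first, only, known or untested is meant among the compounds shown, and "the series" means these compounds.

Measured compounds:
- Compound 1 `Cc1ccc(NC(=O)Nc2ccc3c(c2)COC3=O)cc1`: 2670 nM
- Compound 2 `O=C(Nc1ccc(Cl)cc1)Nc1ccc2c(c1)COC2=O`: 2450 nM
- Compound 3 `O=C(Nc1ccc(I)cc1)Nc1ccc2c(c1)COC2=O`: 1370 nM

All three share one core and differ only in the group on one aromatic carbon of the phenyl ring attached to the urea. In a functional assay on cells (T-cell, Mus musculus) for inhibition (a higher number here means a weaker inhibitor, a lower number a stronger inhibitor), compound 3 gives the lowest of the three numbers, but the gaps to the others are small: a 1.9-fold lower number from compound 1 to compound 3 (0.29 log units; within the scatter) and a 1.8-fold lower number from compound 2 to compound 3 (0.25 log units; within the scatter), and likewise a 1.1-fold lower number from compound 1 to compound 2 (0.04 log units; within the scatter). None of these three steps is large enough to count as a real difference, so the three compounds are best read as equals on this measure.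

Compound 4 `O=C(Nc1ccc2c(c1)COC2=O)NC1CCCCC1` has not yet been measured. It differs from compound 3 in one place: cyclohexyl in place of 4-iodophenyl on an amide-type nitrogen. This is a different kind of change from the three measured steps, which all swapped one small group for another on the same aromatic ring. Within the data shown here, no measured pair in this set exchanges the aromatic ring itself for a saturated one, so no step here bears directly on the move from compound 3 to compound 4. Among the measured compounds shown here, the only guide is that the urea-linked core has so far given numbers in one narrow band regardless of the group on the phenyl ring.

On that basis compound 4 is expected to give 3000 nM, with a plausible range of 700 nM to 13000 nM. The estimated step is a 2.2-fold higher number from compound 3 to compound 4 (0.34 log units; beyond the scatter), with considerable uncertainty because nothing measured here tests a non-aromatic ring in this place.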

Compound 4, half-maximal inhibitory concentration: 12700 nM
The estimate for compound 4 lay 4.2-fold (0.63 log units) below the measured number, within the range that was stated.
By their numbers in this assay, from the lowest: compounds 3, 2 and 1 (each within the scatter of the next); then compound 4.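

The earlier swaps of methyl, chloro and iodo on the phenyl ring all stayed within the scatter, so they gave no sign that this part of the molecule mattered in this assay. Among these compounds, changing the ring itself on the amide-type nitrogen is the first change to go beyond the scatter, giving a 9.3-fold higher number from compound 3 to compound 4 (0.97 log units; beyond the scatter) and a 5.2-fold higher number from compound 2 to compound 4 (0.71 log units; beyond the scatter) and also a 4.8-fold higher number from compound 1 to compound 4 (0.68 log units; beyond the scatter) for the same kind of swap. These steps show that, among these four compounds, a non-aromatic ring of six carbons gives a weaker inhibitor than any of the three substituted phenyl rings, although nothing here accounts for that loss.

Still open, on these data alone, is whether a benzyl group or a straight hexyl chain on that nitrogen would behave like cyclohexyl or like the phenyl compounds. The compounds shown also leave open how the number would respond to an amine or a carboxylic acid on the phenyl ring in place of the iodo group, a kind of group quite unlike the methyl, chloro and iodo tested so far.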